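Adding a Methoxy Group to Compound 1

The source may hold more compounds than are shown below. What is called first, only, known or untested is meant among the compounds shown, and "the series" means these compounds.

Compound 1 `Cn1nnnc1SCC(=O)N/N=c1/scc(-c2ccccc2)n1-c1ccccc1` was tested in an ADME assay on NIH3T3 cells (Mus musculus) for cytotoxicity, read by MTT assay, with a stated time of 24 h (on this read-out higher numbers stand for weaker inhibition and lower numbers for stronger inhibition), and gave 173 ug/mL, the lowest of the two numbers recorded here, so it inhibits cell growth more strongly than its measured neighbour. Compound 2 `O=C(CSc1nnnn1-c1ccccc1)N/N=c1/scc(-c2ccccc2)n1-c1ccccc1` gave 417 ug/mL in this assay. Going by the values given here, the step of a 2.4-fold higher number from compound 1 to compound 2 (0.38 log units; beyond the scatter) is the only single-point comparison available, and it concerns phenyl in place of methyl on an aromatic nitrogen, a different part of the molecule from the change considered next. Compound 3 `Cc1ccc(-c2cs/c(=N/NC(=O)CSc3ncccn3)n2-c2ccccc2)cc1` reached only (the limit of > 500 ug/mL in this assay, at which 1 of the 3 values shown sits), which is a limit of the assay rather than a number, so compound 3 is reported as > 500 ug/mL.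

The new compound 4 `COc1ccc(-c2cs/c(=N/NC(=O)CSc3nnnn3C)n2-c2ccccc2)cc1` differs from compound 1 by methoxy in place of hydrogen on an aromatic carbon. Among the compounds with values here, no measured pair shows this change, and the one measured step touches another site, so it offers little guidance on size or direction. A modest move toward a higher number, or none beyond the scatter, therefore seems most likely. Compound 4 is expected to give about 220 ug/mL in this assay, within 110 ug/mL to 450 ug/mL. That estimate corresponds to a step of a 1.3-fold higher number from compound 1 to compound 4 (0.10 log units; within the scatter).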

Compound 4, half-maximal inhibitory concentration: 45 ug/mL
Estimate against measurement, compound 4: 4.9-fold (0.69 log units) above, and the stated range ends above it.
By their numbers in this assay, from the lowest: compound 4; then compound 1; then compound 2. At a limit, above all of these: compound 3.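

Going from phenyl to 4-methoxyphenyl gives, in this assay, a 3.8-fold lower number from compound 1 to compound 4 (0.58 log units; beyond the scatter), so a group of only 2 heavy atoms at this place on the ring, para to a large group, moves the read-out by more than the usual scatter. The direction is also new: the only earlier step, a 2.4-fold higher number from compound 1 to compound 2 (0.38 log units; beyond the scatter), went toward weaker inhibition with a change on an aromatic nitrogen, while this one goes toward stronger inhibition, so among these three compounds the direction differs between the two sites. Nothing in the data shown explains why methoxy has this effect here.

A single group at a single position cannot show whether the shift belongs to methoxy itself or would also appear with a hydroxyl group, an amine or a chlorine atom in the same place, or with methoxy elsewhere on that ring. Going by these compounds, it also remains open whether the step on the aromatic nitrogen and this one would simply add up if both changes stood in one molecule.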